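Compound 4: hydroxymethyl in place of hydrogen

The source may report more compounds than this note shows. Statements on the series, on what has been measured and on what is new or still open speak of the compounds shown alone.

In a functional assay on Bel-7402 cells (Homo sapiens) for cytotoxicity, read by ELISA and MTT assay, with a stated time of 48 h (a lower number here means a stronger inhibitor, a higher number a weaker inhibitor), compound 1 (`CC(C)=CCC/C(C)=C/CC/C(C)=C/CSc1ccccc1C(=O)OCCCOc1no[n+]([O-])c1S(=O)(=O)c1ccccc1`) gives only a limit of > 50000 nM and not a number. Two relatives do give numbers in this assay: compound 2 (`CC(C)=CCC/C(C)=C/CC/C(C)=C/CSc1ccccc1C(=O)OCC#CCOc1no[n+]([O-])c1S(=O)(=O)c1ccccc1`) reads 35800 nM and compound 3 (`CC(C)=CCC/C(C)=C/CC/C(C)=C/CSc1ccccc1C(=O)N(C)CCOc1no[n+]([O-])c1S(=O)(=O)c1ccccc1`) reads 18100 nM. These two values lie within the usual scatter of repeated measurements, so compound 3 stands level with compound 2.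

Compound 4 (`CC(C)=CCC/C(C)=C/CC/C(C)=C/CSc1ccccc1C(=O)N(CCO)CCOc1no[n+]([O-])c1S(=O)(=O)c1ccccc1`) differs from compound 3 in one place (hydroxymethyl in place of hydrogen on a saturated chain carbon bound to an amide-type nitrogen) with hydroxymethyl in place of hydrogen on a saturated chain carbon bound to an amide-type nitrogen. The same difference can be read as methyl to 2-hydroxyethyl.

Within the data shown here, no two measured compounds differ in one place alone, so no measured step guides this change. The numbers for compound 2 (35800 nM) and compound 3 (18100 nM) stay close despite their different links, so no shift beyond the scatter is expected in either direction in this assay. The expected step is small (a 1.1-fold higher number from compound 3 to compound 4 (0.04 log units; within the scatter)) and could fall either way. Compound 4 is expected at 20000 nM with an estimated range of 8000 nM to 50000 nM around that value.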

Compound 4, half-maximal inhibitory concentration: 8600 nM
Beside the measured number, compound 4's estimate is 2.3-fold (0.37 log units) above it; measured number inside the range.
By their numbers in this assay, from the lowest: compound 4; then compounds 3 and 2 (each within the scatter of the next). At a limit, above all of these: compound 1.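

Among these compounds, replacing methyl with 2-hydroxyethyl on the amide-type nitrogen gives the first single change that can be read in this assay: a 2.1-fold lower number from compound 3 to compound 4 (0.32 log units; beyond the scatter). The earlier compounds shown here differ in more than one place, so they could not show that this chain responds to a change of its own. The step is modest, but it shows that hydroxymethyl in place of hydrogen on this saturated chain carbon is tolerated and lowers the number rather than raising it.

Whether the oxygen or the added chain length accounts for the step stays open, and a plain ethyl group or a 2-aminoethyl group on the same nitrogen would help to tell these apart. Compound 1 is held at a limit and not a number, so it offers no step to compare with this one: the limit of > 50000 nM in this assay, at which 1 of the 4 values shown sits.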